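The source may report more compounds than this note shows. Statements on the series, on what has been measured and on what is new or still open speak of the compounds shown alone.

Compound 3, `COc1ccc(CN(C(=O)C=C(C)C)c2cc(OC)c(OC)c(OC)c2)cc1O`, is one of three measured amides that share a core and differ only in the group on the carbonyl carbon. In a functional assay on KYSE-450 cells (Homo sapiens) for inhibition, read by MTT assay, with a stated time of 48 h (a lower number here means a stronger inhibitor, a higher number a weaker inhibitor), compound 3 gives 280 nM. Compound 1, `COc1ccc(CN(C(=O)C2CC2)c2cc(OC)c(OC)c(OC)c2)cc1O`, carries a cyclopropyl there and in this assay compound 1 gives 80 nM; compound 2, `COc1ccc(CN(C(=O)C[Se]C#N)c2cc(OC)c(OC)c(OC)c2)cc1O`, carries a selenium-bearing chain and in this assay compound 2 gives 280 nM. On these numbers compound 3 stands level with compound 2 and together they hold the highest numbers of the three, while compound 1 is furthest away: the step was a 3.5-fold higher number from compound 1 to compound 3 (0.54 log units; beyond the scatter), and the step was no change at the digits printed from compound 2 to compound 3 (within the scatter).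

Compound 4, `COc1ccc(CN(C(=O)CBr)c2cc(OC)c(OC)c(OC)c2)cc1O`, differs from compound 3 at the same place: bromomethyl in place of 2-methylprop-1-en-1-yl on a carbonyl carbon. Among the compounds with values here, the steps that bear on this are those on the carbonyl carbon: a 3.5-fold higher number from compound 1 to compound 2 (0.54 log units; beyond the scatter) and a 3.5-fold higher number from compound 1 to compound 3 (0.54 log units; beyond the scatter) were modest, and no change at the digits printed from compound 2 to compound 3 (within the scatter) showed nothing beyond the scatter. Since neither exchange among the non-cyclopropyl groups moved the number, compound 4 is expected to sit close to compound 3, with an expected step of a 1.1-fold lower number from compound 3 to compound 4 (0.05 log units; within the scatter). Compound 4 is therefore estimated at 250 nM, in the range 100 nM to 700 nM.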

Compound 4, half-maximal inhibitory concentration: 120 nM
Compound 4: the middle estimate sits 2.1-fold (0.32 log units) above what was measured; the range from low to high includes it.
By their numbers in this assay, from the lowest: compounds 1 and 4 (each within the scatter of the next); then compounds 2 and 3 (each within the scatter of the next).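

The position on the carbonyl carbon turns out to separate the groups other than cyclopropyl: in this assay, bromomethyl in place of 2-methylprop-1-en-1-yl gave a 2.3-fold lower number from compound 3 to compound 4 (0.37 log units; beyond the scatter), and one bromine atom in place of the end of the selenium-bearing chain gave a 2.3-fold lower number from compound 2 to compound 4 (0.37 log units; beyond the scatter). Cyclopropyl no longer stands alone at the low end, as bromomethyl in its place gave a 1.5-fold higher number from compound 1 to compound 4 (0.18 log units; within the scatter), so among these four compounds a ring on this carbonyl carbon is not needed for the lowest numbers. Nothing measured here accounts for these differences.

As far as these compounds go, whether chloromethyl or aminomethyl on the same carbonyl carbon would give a number nearer compound 4 or nearer compound 3 remains open. So does the effect of a larger ring such as cyclobutyl, or of a longer chain carrying bromine.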